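The source may hold more compounds than are shown below. What is called first, only, known or untested is meant among the compounds shown, and "the series" means these compounds.

Measured so far:
compound 1 `O=C(/C=C/c1ccc(Cl)cc1)NS(=O)(=O)c1ccccc1` — 2.2 ug/mL
compound 2 `O=C(/C=C/c1ccc(Br)cc1)NS(=O)(=O)c1ccccc1` — 3.9 ug/mL
compound 3 `Cc1ccc(S(=O)(=O)NC(=O)/C=C/c2ccc(Br)cc2)cc1` — 12.1 ug/mL

These values come from a functional assay on B16-F10 cells (Mus musculus) for antiproliferative activity, read by ELISA and MTT assay, with a stated time of 48 h; on this read-out lower numbers stand for stronger inhibition and higher numbers for weaker inhibition. Compound 2 stands second highest of the three: compound 1 is nearest, with a 1.8-fold higher number from compound 1 to compound 2 (0.25 log units; within the scatter), and compound 3 is furthest, with a 3.1-fold higher number from compound 2 to compound 3 (0.49 log units; beyond the scatter).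

Compound 4 `O=C(/C=C/c1ccc([N+](=O)[O-])cc1)NS(=O)(=O)c1ccccc1` is not yet measured. It differs from compound 2 in one place: nitro in place of bromo on an aromatic carbon.

Going by the values given here, no measured step swaps bromo for nitro. The step from compound 1 to compound 2 exchanges two halogens at this very place and stays within the scatter; the step from compound 2 to compound 3 is modest but changes a different ring. Neither therefore points firmly in a direction, so in this assay no change beyond the scatter is expected, and compound 4 is estimated at 4.5 ug/mL (range 1.5 ug/mL to 13 ug/mL), meaning an expected step of a 1.2-fold higher number from compound 2 to compound 4 (0.06 log units; within the scatter).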

Compound 4, half-maximal inhibitory concentration: 4.8 ug/mL
For compound 4 the middle estimate is 1.1-fold (0.03 log units) below the measured one; measured number inside the range.
By their numbers in this assay, from the lowest: compounds 1, 2 and 4 (each within the scatter of the next, the first and the last beyond it); then compound 3.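

In this assay swapping bromo for nitro at this position gives a 1.2-fold higher number from compound 2 to compound 4 (0.09 log units; within the scatter) and so shows that a group that is not a halogen, with more heavy atoms and with hydrogen-bond acceptors, can sit here without a clear change in the number. Measured against chloro, the same nitro gives a 2.2-fold higher number from compound 1 to compound 4 (0.34 log units; beyond the scatter) and this modest step is the only one at this position that goes beyond the scatter. Nothing measured here explains either step.

As far as these compounds go, it remains open whether an amine or a carboxylic acid at this position would also leave the number largely unchanged. Also open, from the compounds shown here alone, is whether adding a methyl to the other ring of compound 4 would raise the number as it does for compound 2.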